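Swapping the Amide Substituent on a Fluorinated Naphthol Core

A few compounds are considered here, and "the series" means these few. Any claim that something is new, unique, unknown or untested is made for them only; others in the source may bear on it.

Compound 1 `Cc1ccc(O)c(C(O)(C(F)(F)F)C(F)(F)F)c1`: 454000 nM
Compound 2 `O=C(COc1ccc2cc(C(O)(C(F)(F)F)C(F)(F)F)c(O)cc2c1)Nc1nc2ccccc2s1`: 9900 nM

In an assay on isolated protein for inhibition of tyrosine-protein phosphatase non-receptor type 13 (Homo sapiens), read by spectrophotometry (on this read-out lower numbers stand for stronger inhibition and higher numbers for weaker inhibition), compound 1 gives 454000 nM, while compound 2 gives 9900 nM, the lowest of the two numbers, and the gap between them lies well beyond the scatter. Compound 2 extends the small core of compound 1 into a larger, amide-bearing structure.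

Compound 3 `COc1ccc(CNC(=O)COc2ccc3cc(C(O)(C(F)(F)F)C(F)(F)F)c(O)cc3c2)cc1OC` has not yet been measured. It differs from compound 2 in one place: 3,4-dimethoxybenzyl in place of 1,3-benzothiazol-2-yl on an amide-type nitrogen. Going by the values given here, no measured pair shows an exchange of this kind, so there is nothing to calibrate the direction against, and the rest of the molecule is kept unchanged. The step of a 1.5-fold higher number from compound 2 to compound 3 (0.18 log units; within the scatter) is expected to be a modest weakening, close to the edge of the scatter. Compound 3 is therefore estimated at 15000 nM, with a range from 4000 nM to 60000 nM.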

Compound 3, half-maximal inhibitory concentration: > 20000 nM
Compound 3: a limit, no number (the forecaster's own chance of this, stated with the estimate: 10%); at least 1.3-fold (0.12 log units) between middle value and limit.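

In this assay compound 3 gives no number, only a limit of the assay: the limit of > 20000 nM in this assay, at which 1 of the 3 values shown sits.

Going by these compounds alone, the exchange of 1,3-benzothiazol-2-yl for 3,4-dimethoxybenzyl on the amide-type nitrogen gives an at least 2.0-fold higher number from compound 2 to compound 3 (0.30 log units; that floor lies within the scatter), the first reading at this position, and it shows no gain from the change while leaving the true size of the step unknown. The two groups have matching counts of hydrogen-bond donors and acceptors, so these counts do not separate them, although the ring content does differ.

Within the data shown here, with only this one exchange, the ring loss, the added carbon link and the two methoxy groups cannot be told apart. A plain benzyl or a phenyl on the same nitrogen would separate these parts, and a carboxylic acid on the 3,4-dimethoxybenzyl ring remains an open variation too.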